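A few compounds are considered here, and "the series" means these few. Any claim that something is new, unique, unknown or untested is made for them only; others in the source may bear on it.

Compound 3 `COc1ccc(-c2nc(SCC(=O)c3sc(-c4ccc(Cl)cc4)nc3C)nc(N)c2C#N)cc1` is one of three close relatives studied in a functional assay on U-87MG ATCC cells for antiproliferative activity against U-87 MG (Homo sapiens), read by MTT assay, with a stated time of 48 h, tested at 100 uM; a higher number here means a weaker effect of the compound at the concentration tested, a lower number a stronger effect. Compound 1 `COc1ccc(-c2nc(SCC(=O)c3sc(-c4ccccc4)nc3C)nc(N)c2C#N)cc1` gives 17.2%, compound 2 `COc1ccc(-c2nc(C)c(C(=O)CSc3nc(N)c(C#N)c(-c4ccc(OC)cc4)n3)s2)cc1` gives 0.26%, and compound 3 gives 0.79%. Compound 3 thus stands second highest of the three numbers, within the scatter of compound 2 and well beyond it from compound 1, as the drop a number 16.4 percentage points lower from compound 1 to compound 3 (beyond the scatter) shows.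

Compound 4 `Cc1nc(-c2ccc(Cl)cc2)sc1C(=O)CSc1nc(N)c(C#N)c(-c2ccccc2)n1` differs from compound 3 in one place: hydrogen in place of methoxy on an aromatic carbon. Going by the values given here, no measured step touches this ring. Among the compounds with values here, the only step that removes or adds a methoxy, a number 16.9 percentage points lower from compound 1 to compound 2 (beyond the scatter), concerns the other aromatic ring and runs the opposite way, from hydrogen to methoxy, giving a modest change; the chloro step a number 16.4 percentage points lower from compound 1 to compound 3 (beyond the scatter) was of similar size. Read in reverse, that suggests losing a methoxy may raise the number modestly, though on a different ring the transfer is uncertain.

For compound 4 a value of 10% is expected, between 0.5% and 35%. This estimate means a step of a number 9.2 percentage points higher from compound 3 to compound 4 (within the scatter), expected to be upward but not firmly beyond the scatter.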

Compound 4, a percentage reported as activity, at one concentration (the size of the read-out at that concentration, not a potency): 4.59%
Estimate against measurement, compound 4: 5.4 percentage points above, within the range that was stated.
By their numbers in this assay, from the lowest: compounds 2, 3 and 4 (each within the scatter of the next); then compound 1.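

Swapping the 4-methoxyphenyl group for phenyl gives a step in this assay that cannot be told from no change: a number 3.8 percentage points higher from compound 3 to compound 4 (within the scatter). Going by these compounds alone, the earlier compounds showed a methoxy only on the other aromatic ring, where adding it gave a clear step, a number 16.9 percentage points lower from compound 1 to compound 2 (beyond the scatter), so this is the first look at what the group does at this place, with the chloro group held fixed on the far ring. Even so, the two steps cannot be firmly told apart, so the result does not prove that methoxy matters more on one ring than on the other: the same change on two cores in this assay, a number 16.9 percentage points lower (beyond the scatter) from compound 1 to compound 2 and a number 3.8 percentage points lower (within the scatter) from compound 4 to compound 3, 13.1 percentage points apart, within the scatter of two such steps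

As far as these compounds go, it remains open whether a different group at this place, such as an amine, a carboxylic acid or a longer chain like butoxy, would shift the number beyond the scatter. A read-out at a single concentration also leaves open how potency changes across these compounds.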